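Removing the iodine from an aryl ring in a triketone series

A few compounds are considered here, and "the series" means these few. Any claim that something is new, unique, unknown or untested is made for them only; others in the source may bear on it.

Three compounds of one shared core appear here, each carrying a styryl-type enol side chain on the core and differing in the alkyl groups on the core and in the aromatic ring at the far end. Compound 1 `COC1=C(CC=C(C)C)C(=O)/C(=C(O)/C=C/c2ccccc2)C(=O)C1(CC=C(C)C)CC=C(C)C` carries prenyl chains and an unsubstituted phenyl ring; in a functional assay on 1A9 cells (Homo sapiens) for antiproliferative activity, read by sulforhodamine B assay, with a stated time of 3 days (a lower number here means that less compound is needed, a higher number that more compound is needed for the effect), compound 1 gives "not determined" (no result reported). Compound 3 `COC1=C(CCC(C)C)C(=O)/C(=C(O)/C=C/c2ccccc2)C(=O)C1(CCC(C)C)CCC(C)C` carries isopentyl chains and in this assay compound 3 gives 16.3 uM. Compound 2 `CCCC1=C(OC)C(CCC)(CCC)C(=O)/C(=C(O)\C=C\c2ccc(I)cc2)C1=O` carries propyl chains and a 4-iodophenyl ring; in this assay compound 2 gives 1.8 uM, the lower of the two numbers, and the gap from compound 3 to compound 2 lies beyond the scatter.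

Compound 4 `CCCC1=C(OC)C(CCC)(CCC)C(=O)/C(=C(O)\C=C\c2ccccc2)C1=O` keeps the propyl chains of compound 2 and changes only the aromatic ring: hydrogen in place of iodo on an aromatic carbon. The place is para to a large group. Among the measured compounds shown here, no measured pair shows this exact change on this core, so the expectation rests on compound 2 alone and on the general sense that losing a heavy atom from the ring tends to weaken the effect somewhat. The step of a 2.2-fold higher number from compound 2 to compound 4 (0.35 log units; beyond the scatter) is expected to be modest, toward a higher number. Compound 4 is expected to give 4 uM, within a range from 1.5 uM to 12 uM.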

Compound 4, concentration for half-maximal effect: 3.7 uM
For compound 4 the middle estimate is 1.1-fold (0.03 log units) above the measured one, and the stated range covers the measured number.
By their numbers in this assay, from the lowest: compound 2; then compound 4; then compound 3.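

With compound 4 the series gains its first pair that differs in one place only, so the step of a 2.1-fold higher number from compound 2 to compound 4 (0.31 log units; beyond the scatter) in this assay can be tied to a single change: hydrogen in place of iodo on the aromatic ring. This step is modest, although it lies beyond the usual scatter, so removing the iodine moves the number in the higher direction without abolishing the effect, and compound 4 still gives 3.7 uM with an unsubstituted phenyl ring. The data shown offer no measurement that explains this shift.

The compounds shown cover only iodo and hydrogen at this place, so it remains open where a chlorine atom, a methoxy group or an amine in the same position would fall relative to these two results. Also open, from the compounds shown here alone, is whether the same change from 4-iodophenyl to phenyl would give a step of similar size with other chains on the core, such as the isopentyl chains of compound 3 or the prenyl chains of compound 1.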